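Swapping the ring-nitrogen phenyl for a fluorinated methoxyphenyl

The compounds below may be only part of what the source reports. "The series", "measured", "known", "first", "only" and "open" are said of these compounds alone.

Of the compounds shown here, three sharing one core have been tested in a functional assay on HOS-TE85 cells (Homo sapiens) for inhibition, read by CCK-8 assay, with a stated time of 72 h, tested at 1 uM; on this read-out lower numbers stand for less inhibition and higher numbers for more inhibition at the one concentration tested (going by the name of the read-out). Compound 2 `O=C(NCCCCc1ccccc1)c1cccc(C2SCC(=O)N2c2ccccc2)c1` gives 96%; compound 3 `Cc1cccc(N2C(=O)CSC2c2cccc(C(=O)NCCCCc3ccccc3)c2)c1` gives 96%; and compound 1 `COc1ccc(C)cc1N1C(=O)CSC1c1cccc(C(=O)NCCCCc2ccccc2)c1` gives 95%. Compound 2 thus stands level with compound 3 at the digits reported, the two together being the highest of the three numbers, with compound 1 the furthest away and only marginally lower. At the single concentration tested, the three numbers lie within the usual scatter of one another.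

The new compound, compound 4 `COc1c(F)cccc1N1C(=O)CSC1c1cccc(C(=O)NCCCCc2ccccc2)c1`, differs from compound 2 in one place: 3-fluoro-2-methoxyphenyl in place of phenyl on an amide-type nitrogen in a ring.

The steps already measured that bear on this change all alter the same ring attached to the amide-type nitrogen. The step of a number 1 percentage points higher from compound 1 to compound 2 (within the scatter) strips two groups from that ring, the step of a number 1 percentage points higher from compound 1 to compound 3 (within the scatter) removes a methoxy, and the step of no change at the digits printed from compound 2 to compound 3 (within the scatter) adds a methyl. None of these moves the inhibition beyond the usual scatter. Adding a methoxy and a fluorine to the same ring is therefore expected to leave the read-out essentially unchanged, and the estimated step is a number 2 percentage points lower from compound 2 to compound 4 (within the scatter). For compound 4 the expected value in this assay is 94%, with a range from 84% to 99%.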

Compound 4, a percentage reported as inhibition, at one concentration (the size of the read-out at that concentration, not a potency): 12%
Beside the measured number, compound 4's estimate is 82 percentage points above it; measured number below the stated range.
By their numbers in this assay, from the lowest: compound 4; then compounds 1, 2 and 3 (each within the scatter of the next).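

In this assay, going by these compounds alone, the ring on the amide-type nitrogen proves far less forgiving than the earlier compounds suggested, with a step of a number 84 percentage points lower from compound 2 to compound 4 (beyond the scatter) when 3-fluoro-2-methoxyphenyl takes the place of phenyl. A methoxy on this ring does not by itself go with the loss: compound 1 also carries one, within its 2-methoxy-5-methylphenyl, yet the change to the new ring gives a number 83 percentage points lower from compound 1 to compound 4 (beyond the scatter), and the change from 3-methylphenyl gives a number 84 percentage points lower from compound 3 to compound 4 (beyond the scatter). No measurement available here gives a reason for this drop.

The compounds shown leave open whether the fluorine, the methoxy or the particular combination of the two on this ring goes with the loss; a phenyl ring carrying fluorine alone, or a chlorine in place of the fluorine, would help to separate these possibilities. Because each number comes from a single concentration, they also leave open how large the difference in potency is, which a full concentration series on compound 4 and compound 2 would show.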